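Swapping the Biphenyl for a Chlorophenyl on the Shared Core

The source may hold more compounds than are shown below. What is called first, only, known or untested is meant among the compounds shown, and "the series" means these compounds.

Measured compounds:
- compound 1 `Nc1ccccc1NC(=O)c1ccc(COCNc2nc(Nc3ccc(-c4ccccc4)cc3)c3ncn(C4CCCC4)c3n2)cc1`: 41.6%
- compound 2 `CCCn1cnc2c(NCc3ccc(C(=O)Nc4ccccc4N)cc3)nc(Cl)nc21`: 39.2%

Of the compounds shown here, two have been tested in a functional assay on NCI-H460 cells (Homo sapiens) for antiproliferative activity, read by CCK-8 assay, with a stated time of 72 h, tested at 8 uM; a lower number here means a weaker effect, a higher number a stronger effect of the compound at the concentration tested. Compound 1 gives 41.6%, and compound 2 gives 39.2%. The two numbers sit within the usual scatter of each other, so compound 1 cannot be set apart from compound 2 on these data; both show a moderate effect at the concentration tested.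

Compound 3 `Nc1ccccc1NC(=O)c1ccc(COCNc2nc(Nc3cccc(Cl)c3)c3ncn(C4CCCC4)c3n2)cc1` has not yet been measured. It differs from compound 1 in one place: 3-chlorophenyl in place of 4-phenylphenyl on a nitrogen on an aromatic ring. For the measured compounds named here, no pair of measured compounds shows what such a change does in this assay, so there is no measured step to lean on.

With the rest of the molecule kept as in compound 1, the expectation for compound 3 is a value close to that of compound 1, perhaps a little lower, a step that is estimated to stay within the scatter: a number 5.6 percentage points lower from compound 1 to compound 3 (within the scatter). Because compound 1 gives 41.6%, compound 3 is estimated at 36%, with a range from 20% to 52%.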

Compound 3, a percentage reported as inhibition, at one concentration (the size of the read-out at that concentration, not a potency): 49.2%
Compound 3: the middle estimate sits 13.2 percentage points below what was measured; low and high end bracket the measured number.
By their numbers in this assay, from the lowest: compounds 2, 1 and 3 (each within the scatter of the next).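

In this assay, for the compounds shown here, this is the first measured step at this position: a number 7.6 percentage points higher from compound 1 to compound 3 (within the scatter), so compound 1 and compound 3 cannot be told apart. The exchange takes out a group of 12 heavy atoms with two aromatic rings and puts in one of 7 heavy atoms with a single aromatic ring and a chlorine, yet the read-out stays within the usual scatter. At the concentration tested, then, the second aromatic ring of 4-phenylphenyl is not needed for an effect of this size in this pair, and the group on this nitrogen can shrink this far without a measurable loss, although nothing available explains why the pair reads alike.

Two compounds cannot show which part of 3-chlorophenyl matters, so a plain phenyl without the chlorine, or a non-aromatic group such as cyclohexyl or a short alkyl chain, would test whether an aromatic ring or the chlorine is needed here at all. Since each figure comes from a single concentration, the potency of these compounds also remains open.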